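A few compounds are considered here, and "the series" means these few. Any claim that something is new, unique, unknown or untested is made for them only; others in the source may bear on it.

Measured so far:
Compound 1 `CCOC(=O)[C@H](CCC(=O)O)NC(=O)c1ccc(CNc2nc3cc(N)cc(N)c3nc2-c2ccccc2)cc1` gives < 100000 nM in a functional assay on BT-549 cells (Homo sapiens) for inhibition, read by sulforhodamine B assay, with a stated time of 48 h; on this read-out lower numbers stand for stronger inhibition of growth and higher numbers for weaker inhibition of growth; this is a limit of the assay rather than a number.
Compound 2 `COc1ccc(CNc2nc3cc(N)cc(N)c3nc2-c2ccccc2)cc1OC` gives 32400 nM in this assay.
Compound 3 `CCOC(=O)[C@H](CCC(=O)O)NC(=O)c1ccc(Sc2nc3cc(N)cc(N)c3nc2-c2ccccc2)cc1` gives 52500 nM in this assay.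

Among the two actual numbers, compound 2 shows the lowest, but compound 3 sits close enough that the two cannot be told apart; the value of compound 1 stands only as a limit (the limit of < 100000 nM in this assay, at which 1 of the 3 values shown sits). Compound 4 `COc1cc(CNc2nc3cc(N)cc(N)c3nc2-c2ccccc2)cc(OC)c1OC` is built from compound 2 by methoxy in place of hydrogen on an aromatic carbon. Among the compounds with values here, no pair of measured compounds shows this kind of change, so there is no measured step to lean on. The expectation is that the step from compound 2 to compound 4 stays within the scatter, with a 1.1-fold lower number from compound 2 to compound 4 (0.03 log units; within the scatter). Compound 4 is therefore estimated at 30000 nM, expected to fall between 10000 nM and 90000 nM.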

Compound 4, concentration for total growth inhibition: 11200 nM
The estimate for compound 4 lay 2.7-fold (0.43 log units) above the measured number, within the range that was stated.
By their numbers in this assay, from the lowest: compound 4; then compounds 2 and 3 (each within the scatter of the next).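

Methoxy in place of hydrogen on this aromatic carbon, ortho to one methoxy group and meta to another, gives in this assay a 2.9-fold lower number from compound 2 to compound 4 (0.46 log units; beyond the scatter), the first step between measured compounds in this set. So this position does respond to a change, and here growth inhibition becomes stronger. Nothing shown explains the size of this step.

As far as these compounds go, whether the gain belongs to methoxy itself stays open: a hydroxyl, a fluorine or an amine on this carbon would help to tell. From the compounds shown here alone, a longer chain such as ethoxy at this position also remains untested here.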